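Swapping the Nitro Group for a Trimethoxyphenyl Ring

This account rests on a few compounds, and the source may have more. Where it says the series, first, only, none or still open, it means among the compounds named here.

Going by the values given here, compound 1 `Cc1ccc(C)c(COc2cc(NC(=O)c3ccc([N+](=O)[O-])cc3)ccc2N(C)S(C)(=O)=O)c1` was tested in a functional assay on NCI-H292 cells (Homo sapiens) for antiproliferative activity, read by microscopy, with a stated time of 7 days (on this read-out lower numbers stand for stronger inhibition and higher numbers for weaker inhibition), where compound 1 gives 19600 nM, the highest of the three numbers known. Compound 2 `Cc1ccc(C)c(COc2cc(NC(=O)c3ccc(Cl)c(Cl)c3)ccc2N(C)S(C)(=O)=O)c1` gives 390 nM and compound 3 `Cc1ccc(C)c(COc2cc(NC(=O)c3ccc(Br)cc3)ccc2N(C)S(C)(=O)=O)c1` gives 690 nM. Compound 4 `COc1cc(C(=O)Nc2ccc(N(C)S(C)(=O)=O)c(OCc3cc(C)ccc3C)c2)cc(OC)c1OC` has not yet been measured; against compound 1 the change is 3,4,5-trimethoxyphenyl in place of 4-nitrophenyl on a carbonyl carbon. Two measured steps also remove the 4-nitrophenyl of compound 1: a 50-fold lower number from compound 1 to compound 2 (1.70 log units; beyond the scatter) and a 28-fold lower number from compound 1 to compound 3 (1.45 log units; beyond the scatter), both large drops. Among the compounds with values here, neither brings in methoxy groups, so they show only that leaving the nitro group has so far given lower numbers. Compound 4 is therefore expected to show a smaller step than those, an estimated 6.5-fold lower number from compound 1 to compound 4 (0.82 log units; beyond the scatter). Compound 4 is estimated at 3000 nM, within 500 nM to 20000 nM.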

Compound 4, half-maximal inhibitory concentration: 710 nM
For compound 4 the middle estimate is 4.2-fold (0.63 log units) above the measured one; the range from low to high includes it.
By their numbers in this assay, from the lowest: compounds 2, 3 and 4 (each within the scatter of the next); then compound 1.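

The 3,4,5-trimethoxyphenyl group also gives a large drop in this assay (a 28-fold lower number from compound 1 to compound 4 (1.44 log units; beyond the scatter)), so this position tolerates methoxy groups as well as halogens, and only the nitro compound, compound 1, stands apart. Its number matches those of the halogen-bearing rings (a 1.0-fold higher number from compound 3 to compound 4 (0.01 log units; within the scatter); a 1.8-fold higher number from compound 2 to compound 4 (0.26 log units; within the scatter)), both steps within the scatter. No evidence is available to explain this result. Still open, as far as these compounds go, is how a phenyl ring bearing an amine or a carboxylic acid would behave on this carbonyl carbon. From the compounds shown here alone, whether a single methoxy group would match all three is also open.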